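This account rests on a few compounds, and the source may have more. Where it says the series, first, only, none or still open, it means among the compounds named here.

Measured compounds:
compound 1 `N#Cc1ccc(OCc2nnc(-c3ccc(F)cc3)o2)cc1F`; in a functional assay on MDA-MB-453 cells (Homo sapiens) for cytotoxicity, read by MTT assay, with a stated time of 48 h (on this read-out higher numbers stand for weaker inhibition and lower numbers for stronger inhibition), compound 1 gives 25100 nM.
compound 2 `N#Cc1ccc(OCc2nnc(-c3ccc(Cl)cc3)o2)cc1F`; in this assay compound 2 gives > 50000 nM, which is a limit of the assay and not a number.
compound 3 `Fc1ccc(-c2nnc(COc3ccc(-c4nnco4)cc3)o2)cc1`; in this assay compound 3 gives 38200 nM.

The change from compound 1 to compound 2, (chloro in place of fluoro on an aromatic carbon), gives an at least 1.9-fold higher number from compound 1 to compound 2 (0.29 log units; that floor lies within the scatter); the floor of that step rests on (the limit of > 50000 nM in this assay, at which 1 of the 3 values shown sits). Compound 3 and compound 1 differ in more than one place; the difference between the two cores is not broken down here. Compound 4 `Clc1ccc(-c2nnc(COc3ccc(-c4nnco4)cc3)o2)cc1` is not yet measured. It differs from compound 3 by chloro in place of fluoro on an aromatic carbon, the same change as from compound 1 to compound 2, at the same place. In this assay the step from compound 3 to compound 4 is expected at a 1.7-fold higher number from compound 3 to compound 4 (0.23 log units; within the scatter), set beside the earlier step and resting on an at least 1.9-fold higher number from compound 1 to compound 2 (0.29 log units; that floor lies within the scatter) and on compound 3 at 38200 nM. Compound 4 is therefore expected near 65000 nM, with a range from 30000 nM to 150000 nM, and a limit rather than a number is likely.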

Compound 4, half-maximal inhibitory concentration: > 50000 nM
Compound 4: a limit, no number; the forecaster's own chance of this, stated with the estimate: 60%; the middle value is on the limit's open side.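

Compound 4 gives > 50000 nM in this assay, which is a limit of the assay and not a number. Chloro in place of fluoro therefore reads only as a floor, an at least 1.3-fold higher number from compound 3 to compound 4 (0.11 log units; that floor lies within the scatter), and that floor does not establish a real loss on this core. Both chloro compounds end at the limit, so nothing shows the change behaving differently on the two cores, but neither its size on either core nor any agreement in size is shown: the same change on two cores in this assay, an at least 1.9-fold higher number (0.29 log units; that floor lies within the scatter) from compound 1 to compound 2 and an at least 1.3-fold higher number (0.11 log units; that floor lies within the scatter) from compound 3 to compound 4; the limit leaves it open whether they differ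

As far as these compounds go, it remains open how an amine or a methoxy group in place of the fluoro or chloro would read on either core. Any further chloro comparison in this series stays bounded on one side only: the limit of > 50000 nM in this assay, at which 2 of the 4 values shown sit.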